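Swapping the Amide Ring Substituent and Cell Toxicity

A few compounds are considered here, and "the series" means these few. Any claim that something is new, unique, unknown or untested is made for them only; others in the source may bear on it.

Compound 1, `Cc1cc(C)cc(S(=O)(=O)c2c(C(=O)N[C@@H]3CCN(Cc4ccccc4C#N)C3)[nH]c3ccc(Cl)cc23)c1`, in an ADME assay on MT4 cells (Homo sapiens) for cytotoxicity, read by MTT assay, with a stated time of 5 days (on this read-out higher numbers stand for lower toxicity in this test and lower numbers for higher toxicity in this test), gives only a limit of the assay, >= 186000 nM.
Compound 2, `Cc1cc(C)cc(S(=O)(=O)c2c(C(=O)N[C@@H]3CCN(S(C)(=O)=O)C3)[nH]c3ccc(Cl)cc23)c1`, in this assay gives 24000 nM.

Compound 2 therefore holds the only true number shown; the other value is a limit, so it stands alone and cannot be ranked against anything. Compound 3, `Cc1cc(C)cc(S(=O)(=O)c2c(C(=O)NC3CN(Cc4ccccc4F)C3)[nH]c3ccc(Cl)cc23)c1`, differs from compound 2 in one place: 1-(2-fluorobenzyl)azetidin-3-yl in place of 1-(methylsulfonyl)pyrrolidin-3-yl on an amide-type nitrogen. For the measured compounds named here, only one measured step bears on this change, an at least 7.7-fold lower number from compound 1 to compound 2 (0.88 log units; beyond the scatter), in which a methylsulfonyl took the place of a 2-cyanobenzyl on the ring nitrogen and the number fell, meaning higher toxicity in this test. Compound 3 moves in the opposite sense, putting a benzyl-type group back on the ring nitrogen, although the ring shrinks to four members and the substituent on the aromatic ring is fluorine rather than nitrile, so it is not a clean reversal. A higher number, of comparable size to that step, is therefore expected for compound 3, a 4.2-fold higher number from compound 2 to compound 3 (0.62 log units; beyond the scatter), and it may again reach the limit. Compound 3 is estimated at 100000 nM, within 30000 nM to 200000 nM.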

Compound 3, half-maximal cytotoxic concentration: > 238000 nM
Compound 3: a limit, no number (the forecaster's own chance of this, stated with the estimate: 40%); middle value at least 2.3-fold (0.37 log units) away from the limit.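

In this assay compound 3 gives > 238000 nM, which is a limit of the assay and not a true number. Placing 1-(2-fluorobenzyl)azetidin-3-yl on the amide-type nitrogen instead of 1-(methylsulfonyl)pyrrolidin-3-yl gives an at least 9.9-fold higher number from compound 2 to compound 3 (0.99 log units; beyond the scatter), which means lower toxicity in this test, and the real size of the change could be larger still. This shows that the higher read-out at this position is not confined to the 2-cyanobenzyl group on a five-membered ring, yet compound 2 remains the only compound here with a true number: the limit of > 238000 nM in this assay, at which 1 of the 3 values shown sits.

The four-membered ring and the benzyl-type group enter together, so the step cannot be divided between them, and a comparison with 1-(2-fluorobenzyl)pyrrolidin-3-yl or 1-(methylsulfonyl)azetidin-3-yl would be needed to separate the two. As far as these compounds go, it also remains open how the read-out would respond to a simple acetyl group or an unsubstituted ring amine at this ring nitrogen, where the result could show whether the methylsulfonyl group is unusual in giving a true number.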